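A few compounds are considered here, and "the series" means these few. Any claim that something is new, unique, unknown or untested is made for them only; others in the source may bear on it.

Of the compounds shown here, three of one shared core have been measured in a functional assay on HeLa cells (Homo sapiens) for antiproliferative activity, read by MTT assay, with a stated time of 72 h; on this read-out higher numbers stand for weaker inhibition and lower numbers for stronger inhibition. Compound 1 `CCCCCCc1cc2cn(Cc3cn(Cc4ccccc4)nn3)c(=O)nc2o1` gives 59400 nM. Compound 2 `O=c1nc2oc(C3CC3)c(C#CC3CC3)c2cn1Cc1cn(Cc2ccccc2)nn1` gives 6510 nM. Compound 3 `O=c1nc2oc(CCCCl)c(C#CCCCCCl)c2cn1Cc1cn(-c2ccc(F)cc2)nn1` gives 41800 nM, the second highest of the three numbers: its nearest neighbour is compound 1, whose number lies within the usual scatter of it, while the number of compound 2 lies well apart, beyond the scatter, on the stronger side.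

Compound 4 `O=c1nc2oc(CCCCl)cc2cn1Cc1cn(-c2ccc(F)cc2)nn1` has not yet been measured. It differs from compound 3 in one place: hydrogen in place of 6-chlorohex-1-yn-1-yl on an aromatic carbon. Among the measured compounds, the one without any such group on that carbon, compound 1, shows the weakest inhibition by its value 59400 nM, whereas compound 2, which carries a group there, stands clearly stronger at 6510 nM. On this slim basis, a weakening of modest size is expected in this assay, though a step that stays within the scatter is also plausible. The value of compound 4 is estimated at 65000 nM, within a range from 22000 nM to 180000 nM, which would mean an expected step of a 1.6-fold higher number from compound 3 to compound 4 (0.19 log units; within the scatter).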

Compound 4, half-maximal inhibitory concentration: 6990 nM
Estimate against measurement, compound 4: 9.3-fold (0.97 log units) above, and the stated range ends above it.
By their numbers in this assay, from the lowest: compounds 2 and 4 (each within the scatter of the next); then compounds 3 and 1 (each within the scatter of the next).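

In this assay the change from the 6-chlorohex-1-yn-1-yl group to hydrogen gives a 6.0-fold lower number from compound 3 to compound 4 (0.78 log units; beyond the scatter) and so points to stronger inhibition, a step beyond the scatter. Among these compounds, compound 3 and compound 4 are the first pair here that differ in one place, which makes this the first direct reading of this aromatic carbon. With the 3-chloropropyl group and the rest of the molecule kept, the long chain is not needed for this activity in this pair, and nothing measured here explains the direction of the step.

On these data alone, it remains open whether the difference follows the triple bond, the chain length or the chlorine at the chain end, since only the whole group and hydrogen are compared on this carbon. An ethynyl group or an amine at this place, with the rest of compound 4 kept, would help separate these parts.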